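Chloro for trifluoromethyl in the methyl ether pair

This account rests on a few compounds, and the source may have more. Where it says the series, first, only, none or still open, it means among the compounds named here.

In a functional assay on U-251 cells (Homo sapiens) for inhibition, read by sulforhodamine B assay, with a stated time of 48 h, tested at 100 uM (a lower number here means a stronger effect, a higher number a weaker effect of the compound at the concentration tested), compound 1 `O=C(Nc1cccc(-n2cc(-c3ccncc3)c(-c3cc(O)cc(Cl)c3)n2)c1)Nc1ccc(Cl)c(C(F)(F)F)c1` gives -84%, while compound 2 `O=C(Nc1cccc(-n2cc(-c3ccncc3)c(-c3cc(O)cc(Cl)c3)n2)c1)Nc1ccc(Cl)c(Cl)c1` gives -57%. Compound 3 `COc1cc(Cl)cc(-c2nn(-c3cccc(NC(=O)Nc4ccc(Cl)c(C(F)(F)F)c4)c3)cc2-c2ccncc2)c1` gives -100% in this assay, the lowest of the three numbers; its nearest neighbour is compound 1, with a number 16 percentage points lower from compound 1 to compound 3 (beyond the scatter) between them, and compound 2 stands further off, both gaps beyond the scatter.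

Compound 4 `COc1cc(Cl)cc(-c2nn(-c3cccc(NC(=O)Nc4ccc(Cl)c(Cl)c4)c3)cc2-c2ccncc2)c1` is compound 3 altered at one place: chloro in place of trifluoromethyl on an aromatic carbon. For the measured compounds named here, one measured step bears directly on this change, made on the pair carrying hydrogen on the oxygen rather than methyl: there it read a number 27 percentage points higher from compound 1 to compound 2 (beyond the scatter), a modest shift beyond the scatter. The methyl-for-hydrogen step, a number 16 percentage points lower from compound 1 to compound 3 (beyond the scatter), does not concern the swap itself but shows the methyl ether pair sitting lower than its counterpart. Carrying the measured shift over, the expected result for compound 4 is a number 27 percentage points higher from compound 3 to compound 4 (beyond the scatter) in this assay, a modest step upward rather than none beyond the scatter, resting on a single precedent. The estimate for compound 4 in this assay is -73%, with a range from -95% to -45%.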

Compound 4, a percentage reported as activity, at one concentration (the size of the read-out at that concentration, not a potency): -68%
Estimate against measurement, compound 4: 5 percentage points below, within the range that was stated.
By their numbers in this assay, from the lowest: compound 3; then compound 1; then compound 4; then compound 2.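

Notes on the series: in this assay, chloro in place of trifluoromethyl on the aromatic carbon ortho to a chloro group now has a second reading, a number 32 percentage points higher from compound 3 to compound 4 (beyond the scatter), so the upward move no longer rests on the pair with hydrogen on the oxygen alone. The size of the move also holds across the two cores: the same change on two cores in this assay, a number 27 percentage points higher (beyond the scatter) from compound 1 to compound 2 and a number 32 percentage points higher (beyond the scatter) from compound 3 to compound 4, 5 percentage points apart, within the scatter of two such steps. The methyl-for-hydrogen change on the oxygen likewise gains a second reading on the 3,4-dichlorophenyl side, a number 11 percentage points lower from compound 2 to compound 4 (beyond the scatter), and within these four compounds the two changes show no dependence on each other: the same change on two cores in this assay, a number 16 percentage points lower (beyond the scatter) from compound 1 to compound 3 and a number 11 percentage points lower (beyond the scatter) from compound 2 to compound 4, 5 percentage points apart, within the scatter of two such steps.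

Open, as far as these compounds go, is how other groups in place of trifluoromethyl at this position would read, such as bromo, methyl or nitrile, and whether a longer chain on the oxygen, such as an ethyl ether, would extend the methyl-for-hydrogen shift. All these readings come from one concentration, so they give the size of the effect there and say only which compound has the stronger or weaker effect at that concentration.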